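This account rests on a few compounds, and the source may have more. Where it says the series, first, only, none or still open, it means among the compounds named here.

Working notes on the shared core, assayed in a functional assay on MCF7 cells (Homo sapiens) for inhibition, read by sulforhodamine B assay; a lower number here means a stronger inhibitor, a higher number a weaker inhibitor. Compound 1 `O=C1C=C(Nc2ccc(I)cc2)C(=O)c2c1nc1n2[C@H]2OC[C@@H](O)[C@H]2OC1` gives 2230 nM in this assay. Compound 2 `COc1cccc(NC2=CC(=O)c3nc4n(c3C2=O)[C@H]2OC[C@@H](O)[C@H]2OC4)c1` gives only a limit in this assay, > 4000 nM. Compound 3 `O=C1C=C(N2CCCCC2)C(=O)c2c1nc1n2[C@H]2OC[C@@H](O)[C@H]2OC1` also gives only a limit in this assay, > 8000 nM. Among the three values shown, compound 3 therefore stands at a limit rather than at a number: the step of an at least 3.5-fold higher number from compound 1 to compound 3 (0.55 log units; beyond the scatter) is readable in direction and floor only, and the step that the two limits leave unreadable from compound 2 to compound 3 cannot be sized because both ends rest on the limit of > 4000 nM in this assay, at which 1 of the 3 values shown sits, and (the limit of > 8000 nM in this assay, at which 1 of the 3 values shown sits).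

Compound 4 `CCCN(CCC)C1=CC(=O)c2nc3n(c2C1=O)[C@H]1OC[C@@H](O)[C@H]1OC3` differs from compound 3 in one place: dipropylamino in place of piperidin-1-yl on a double-bonded ring carbon. For the measured compounds named here, none of the measured steps exchanges one saturated amine for another; the one step that ends at compound 3 with a readable floor, an at least 3.5-fold higher number from compound 1 to compound 3 (0.55 log units; beyond the scatter), concerns an aryl amino group and tells nothing about opening the ring. The expected step that the limit leaves unreadable from compound 3 to compound 4 is therefore set at nothing beyond the scatter, with compound 3 already at a limit. Compound 4 is expected near 10000 nM, within 4000 nM to 30000 nM, most likely again reported only as a limit.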

Compound 4, half-maximal inhibitory concentration: > 16000 nM
Compound 4: no number, only a limit; the forecaster's own chance of this, stated with the estimate: 70%; middle value at least 1.6-fold (0.20 log units) away from the limit.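

Replacing piperidin-1-yl with dipropylamino on the double-bonded ring carbon again gives no number in this assay, so opening the ring of the saturated amine cannot be sized, and the steps to compound 4 from compound 2 and compound 3 cannot be read. For the compounds shown here, the one readable step is an at least 7.1-fold higher number from compound 1 to compound 4 (0.85 log units; beyond the scatter), which shows that a second amine without an aryl group, this one with no ring, also stands clearly apart from the (4-iodophenyl)amino group of compound 1. Compound 4 is known only through a limit of its own: the limit of > 16000 nM in this assay, at which 1 of the 4 values shown sits.

Any difference between piperidin-1-yl and dipropylamino at this position stays open, with compound 3 and compound 4 both resting on limits. Going by these compounds alone, also open is how a morpholine, a dimethylamino group or a (4-chlorophenyl)amino group on the same carbon would read against compound 1, the only compound here with a number.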